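Acetyl to Benzoyl: What Compound 4 May Show

The source may report more compounds than this note shows. Statements on the series, on what has been measured and on what is new or still open speak of the compounds shown alone.

Three compounds built on one shared core were examined in an ADME assay (MDM cells, Homo sapiens) for cytotoxicity, read by resazurin assay, with a stated time of 3 days; on this read-out lower numbers stand for stronger inhibition and higher numbers for weaker inhibition. Compound 2 `CCCSc1nnc(COc2ccccc2C2=NOC(c3ccc(Cl)cc3Cl)C2)n1NC(=O)c1ccccc1` gives 14.8 ug/mL. Compound 3 `CSc1nnc(COc2ccccc2C2=NOC(c3ccc(Cl)cc3Cl)C2)n1NC(C)=O` gives 2.7 ug/mL, the lower of the two numbers; the gap up to compound 2 lies beyond the usual scatter of this assay. For compound 1 `CC(C)CSc1nnc(COc2ccccc2C2=NOC(c3ccc(Cl)cc3Cl)C2)n1NC(=O)c1ccccc1` the entry in this assay reads "not determined" (no result reported), so no result was reported for it.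

Compound 4 `CSc1nnc(COc2ccccc2C2=NOC(c3ccc(Cl)cc3Cl)C2)n1NC(=O)c1ccccc1` has not yet been measured. It differs from compound 3 in one place only: phenyl in place of methyl on a carbonyl carbon, which one bond further out reads acetyl to benzoyl, or acetamido to benzamido. Among the compounds with values here, no pair of measured compounds isolates exactly this change. Compound 2 carries the same benzamido group, though alongside a propylthio chain rather than the methylthio of compound 4, and it gives the higher number. That comparison rests on two differences at once, so it only hints at the direction.

On that basis compound 4 is expected to move upward from compound 3 by a 2.6-fold higher number from compound 3 to compound 4 (0.41 log units; beyond the scatter), a step somewhat beyond the scatter but short of the gap to compound 2. The estimate for compound 4 is 7 ug/mL, with a range from 2.5 ug/mL to 20 ug/mL.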

Compound 4, half-maximal inhibitory concentration: 2.2 ug/mL
Beside the measured number, compound 4's estimate is 3.2-fold (0.50 log units) above it; measured number below the stated range.
By their numbers in this assay, from the lowest: compounds 4 and 3 (each within the scatter of the next); then compound 2.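

In this assay, with the methylthio chain held fixed, acetyl to benzoyl on its own gives a step that stays within the scatter (a 1.2-fold lower number from compound 3 to compound 4 (0.09 log units; within the scatter)), so on this carbonyl carbon the read-out does not distinguish methyl from phenyl in this pair. With the benzamido group held fixed, hydrogen in place of ethyl on the saturated chain carbon bound to a sulfur gives a step beyond the scatter (a 6.7-fold lower number from compound 2 to compound 4 (0.83 log units; beyond the scatter)), so the higher number of compound 2 goes with its propylthio chain, not with the benzamido group that it shares with compound 4. Nothing available explains why the chain on sulfur shows a step here while the group on the carbonyl carbon does not.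

The compounds shown leave open whether this flat response on the carbonyl carbon would hold for a pyridine ring or a tert-butyl group in place of phenyl, since a single pair cannot show how far it extends. They also leave open how the read-out would respond to an ethyl chain on sulfur, or to a chain on sulfur ending in a carboxylic acid or an amine.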